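Adding a second chloro group to compound 2

The source may hold more compounds than are shown below. What is called first, only, known or untested is meant among the compounds shown, and "the series" means these compounds.

Compound 1 `COc1cc(CCc2ccccc2Cl)cc(OC)c1O`: 21100 nM
Compound 2 `COc1cc(CCc2ccc(Cl)cc2)cc(OC)c1O`: > 25000 nM (a limit)

Of the compounds shown here, two sharing one core have been tested in a functional assay on MDA-MB-231 cells (Homo sapiens) for antiproliferative activity, read by MTT assay, with a stated time of 72 h; on this read-out higher numbers stand for weaker inhibition and lower numbers for stronger inhibition. In this assay compound 1 gives a measured number, 21100 nM. Compound 2 gives no number, and its > 25000 nM is only a limit of the assay. Compound 2 therefore stands at the top of the measurable range, with no exact position known.

Compound 3 `COc1cc(CCc2ccc(Cl)cc2Cl)cc(OC)c1O` follows from compound 2 by one change, chloro in place of hydrogen on an aromatic carbon. Within the data shown here, no step between measured compounds is available to size this change in this assay. Among the measured compounds shown here, the only guide is that compound 1, which also carries a single chloro group, reaches 21100 nM, so a reading near that level seems plausible. A modest move toward stronger inhibition is expected, an estimated at least 1.4-fold lower number from compound 2 to compound 3 (0.16 log units; that floor lies within the scatter), and a second reading at the limit would not be surprising. The estimate for compound 3 is 17000 nM, with an expected range from 7000 nM to 35000 nM.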

Compound 3, half-maximal inhibitory concentration: > 25000 nM
Compound 3: only a limit was reported; the forecaster's own chance of this, stated with the estimate: 35%; middle value at least 1.4-fold (0.16 log units) from the limit.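

In this assay compound 3 gives > 25000 nM, a limit and not a number, so a chloro group placed ortho to a large group and meta to a chloro group does not bring compound 2 into the measurable range, and the step between these two cannot be read. The same kind of change, made on the single-chloro compound that does give a number, shows an at least 1.1-fold higher number from compound 1 to compound 3 (0.07 log units; that floor lies within the scatter), and since that floor lies within the scatter, the data show no gain in inhibition from a second chloro group on this aromatic ring. Only one of the three compounds now gives a number, which leaves little to compare: the limit of > 25000 nM in this assay, at which 2 of the 3 values shown sit.

On these data alone, how far compound 2 and compound 3 lie past that limit remains unknown, so it stays open whether the second chloro group weakens inhibition or leaves it unchanged. As far as these compounds go, it is also open whether a fluoro group or an amine at this same place would bring the reading back into the measurable range.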